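Swapping Fluorine for Chlorine on a Selenocyanate Carbamate

This account rests on a few compounds, and the source may have more. Where it says the series, first, only, none or still open, it means among the compounds named here.

Of the compounds shown here, three sharing a selenium-bearing core have been measured in an ADME assay on 184B5 cells (Homo sapiens) for cytotoxicity, read by MTT assay, with a stated time of 72 h; on this read-out lower numbers stand for stronger inhibition of growth and higher numbers for weaker inhibition of growth. Compound 1 `CCCCOC(=O)Nc1ccc([Se]C#N)cc1` gives 5300 nM. Compound 2 `N#C[Se]c1ccc(NC(=O)Oc2ccc(F)cc2)cc1` gives 6900 nM. Compound 3 `CCCCOC(=O)Nc1ccc([Se][Se]c2ccc(NC(=O)OCCCC)cc2)cc1` gives 7200 nM. Compound 2 stands second highest of the three numbers; compound 3 is its nearest neighbour and compound 1 its furthest, yet both gaps lie within the usual scatter of repeated measurements, so none of the three can be called stronger or weaker than another.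

Compound 4 `N#C[Se]c1ccc(NC(=O)Oc2ccc(Cl)cc2)cc1` has not yet been measured. It differs from compound 2 in a single place: chloro in place of fluoro on an aromatic carbon. For the measured compounds named here, no pair of measured compounds in this set shows that same exchange, so there is no measured step to lean on. A change of one halogen for another at the same position is expected to move the number little, if at all, beyond the scatter, in no firm direction.

For compound 4 the expected value in this assay is 6000 nM, with a range from 2500 nM to 15000 nM. The step from compound 2 to compound 4 that this estimate means is a 1.2-fold lower number from compound 2 to compound 4 (0.06 log units; within the scatter), which is expected to remain within the scatter.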

Compound 4, concentration for 50% growth inhibition: 5600 nM
Beside the measured number, compound 4's estimate is 1.1-fold (0.03 log units) above it; the range from low to high includes it.
By their numbers in this assay, from the lowest: compounds 1, 4, 2 and 3 (each within the scatter of the next).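

In this assay, for the compounds shown here, the set now holds a 1.2-fold lower number from compound 2 to compound 4 (0.09 log units; within the scatter) for chloro in place of fluoro on an aromatic carbon, the first measured exchange of one halogen for another at this place, para to a large group. On this read-out, then, compound 2 and compound 4 cannot be told apart, and this position carries either halogen with no step beyond the scatter. No supporting measurement is available to explain this result.

Still open, going by these compounds, is whether a group of another kind at this position, such as an amine, a carboxylic acid or a methoxy group, would move the number beyond the scatter. Also open, on these data alone, is whether a heavier halogen such as bromo, or removing the halogen to leave hydrogen, would do so.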